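Swapping a saturated ring for an aromatic one

The compounds below may be only part of what the source reports. "The series", "measured", "known", "first", "only" and "open" are said of these compounds alone.

Among the compounds with values here, the two compounds measured so far share one core and differ only in the ring that carries the methyl ester. Compound 1 `COC(=O)C1CCCCC1c1ccc(CNc2nccc(C)c2NC(=O)CC#N)cc1` holds a cyclohexane ring there, and in a physicochemical assay for lipophilicity (on this read-out lower numbers stand for lower lipophilicity and higher numbers for higher lipophilicity), compound 1 gives 2.7. Compound 2 `COC(=O)C1C2CCC(CC2)C1c1ccc(CNc2nccc(C)c2NC(=O)CC#N)cc1` holds a bridged bicyclic ring instead; in this assay compound 2 gives 3.4, and the gap between the two lies beyond the usual scatter, so compound 1 stands as the lower of the two.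

Compound 3 `COC(=O)c1ccccc1-c1ccc(CNc2nccc(C)c2NC(=O)CC#N)cc1` has not yet been measured. It differs from compound 1 in one place: 2-(methoxycarbonyl)phenyl in place of 2-(methoxycarbonyl)cyclohexyl on an aromatic carbon. Nothing measured here covers such a swap, so the size of the step is uncertain. The expected step from compound 1 to compound 3 in this assay is a number 0.40 log units lower from compound 1 to compound 3 (beyond the scatter), a modest decrease in lipophilicity. For compound 3 the value expected in this assay is 2.3, with a likely range from 1.7 to 2.9.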

Compound 3, partition coefficient: 2.5
Beside the measured number, compound 3's estimate is 0.20 log units below it, within the range that was stated.
By their numbers in this assay, from the lowest: compounds 3 and 1 (each within the scatter of the next); then compound 2.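

On this position, on an aromatic carbon para to a large group, putting 2-(methoxycarbonyl)phenyl in place of 2-(methoxycarbonyl)cyclohexyl gives, in this assay, a number 0.20 log units lower from compound 1 to compound 3 (within the scatter). A six-membered aromatic ring of carbon only and a six-membered non-aromatic ring of carbon only, each carrying the same ester and the same count of heavy atoms, therefore cannot be told apart on this read-out at this position. Nothing measured here speaks to why the two groups read so much alike.

Still open, as far as these compounds go, is whether a change of atoms within the ring, such as a pyridine in place of the phenyl, would stay as close in this assay. The same question stands for a carboxylic acid or an amine in place of the methyl ester on the aromatic ring.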